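The source may report more compounds than this note shows. Statements on the series, on what has been measured and on what is new or still open speak of the compounds shown alone.

Three compounds have been measured in an ADME assay for permeability, using PAMPA, with a stated time of 30 min, at pH 7.4; on this read-out lower numbers stand for lower permeability and higher numbers for higher permeability:
compound 1 `COc1ccc(F)cc1CNCCCNc1ccnc2cc(Cc3ccc(C#N)cc3)ccc12` gives 23 10^-6 cm/s;
compound 2 `COc1ccc(F)cc1CNCCCNc1ccnc2cc(-c3cccc4ccccc34)ccc12` gives 237 10^-6 cm/s;
compound 3 `COc1ccc(F)cc1CNCCCNc1ccnc2cc(Cc3cccc(C(F)(F)F)c3)ccc12` gives 23 10^-6 cm/s.

Compound 3 thus stands level with compound 1, the two together the lowest of the three, while the step from compound 2 to compound 3 is a 10-fold lower number from compound 2 to compound 3 (1.01 log units; beyond the scatter). The next compound, compound 4 `COc1ccc(F)cc1CNCCCNc1ccnc2cc(Oc3ccc(Cl)cc3)ccc12`, has not yet been measured. Its change from compound 3 is this: 4-chlorophenoxy in place of 3-(trifluoromethyl)benzyl on an aromatic carbon. For the measured compounds named here, two measured steps bear on it: no change at the digits printed from compound 1 to compound 3 (within the scatter), between two benzyl groups, and a 10-fold lower number from compound 2 to compound 3 (1.01 log units; beyond the scatter), between a naphthalen-1-yl group and a benzyl group. The entering group is neither; like the naphthalen-1-yl it sits on an aromatic carbon without a chain carbon in between. For compound 4 a step toward higher numbers in this assay is therefore expected, though a modest one, estimated at a 1.7-fold higher number from compound 3 to compound 4 (0.24 log units; within the scatter). Compound 4 is expected to give 40 10^-6 cm/s, within the range 15 10^-6 cm/s to 110 10^-6 cm/s.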

Compound 4, apparent permeability in the ADME assay: 317 10^-6 cm/s
For compound 4 the middle estimate is 7.9-fold (0.90 log units) below the measured one; measured number outside the range, above it.
By their numbers in the ADME assay, from the lowest: compounds 1 and 3 (each within the scatter of the next); then compounds 2 and 4 (each within the scatter of the next).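

In the ADME assay the high numbers at this position are not confined to naphthalen-1-yl: 4-chlorophenoxy brings a 14-fold higher number from compound 3 to compound 4 (1.14 log units; beyond the scatter) and a 14-fold higher number from compound 1 to compound 4 (1.14 log units; beyond the scatter) while a 1.3-fold higher number from compound 2 to compound 4 (0.13 log units; within the scatter) keeps it with the naphthalen-1-yl compound. For the compounds shown here, in a physicochemical assay for acid dissociation, compound 3 gives 9.47 and compound 4 gives 9.28 with a number 0.19 log units lower from compound 3 to compound 4 (within the scatter) so this read-out shows no matching large step. Nothing at hand accounts for the step in the ADME assay. Open, on these data alone, is whether the ring oxygen or the chlorine goes with the higher number, and how a phenylamino or a 4-carboxyphenoxy group would read here.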